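Replacing the aryl group on compound 3's amide

The source may hold more compounds than are shown below. What is called first, only, known or untested is meant among the compounds shown, and "the series" means these compounds.

Measured compounds:
- compound 1 `CN(C)C(=O)c1cc2cnc(Nc3ccc(NC(=O)C4(C(=O)Nc5cccc(F)c5)CC4)cc3)nc2n1C1CCCC1` gives 64.2%
- compound 2 `CN(C)C(=O)c1cc2cnc(Nc3ccc(NC(=O)C4(C(=O)Nc5cccc(O)c5)CC4)cc3)nc2n1C1CCCC1` gives 77.5%
- compound 3 `CN(C)C(=O)c1cc2cnc(Nc3ccc(NC(=O)C4(C(=O)Nc5ccccc5F)CC4)cc3)nc2n1C1CCCC1` gives 70.2%

All three were tested in a functional assay on NCI-H1299 cells (Homo sapiens) for inhibition, read by CCK-8 assay, with a stated time of 72 h, tested at 1 uM; on this read-out higher numbers stand for more inhibition of growth at the one concentration tested and lower numbers for less inhibition of growth. Compound 3, at 70.2%, lies within the scatter of both other compounds. Its two steps are a number 6 percentage points higher from compound 1 to compound 3 (within the scatter) and a number 7.3 percentage points lower from compound 2 to compound 3 (within the scatter).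

Compound 4 `CN(C)C(=O)c1cc2cnc(Nc3ccc(NC(=O)C4(C(=O)Nc5ccc(Cl)c(C(F)(F)F)c5)CC4)cc3)nc2n1C1CCCC1` differs from compound 3 at one place, on an amide-type nitrogen: 4-chloro-3-(trifluoromethyl)phenyl in place of 2-fluorophenyl on an amide-type nitrogen. Among the compounds with values here, two measured steps change the group at this same place and stay within the scatter, the one to compound 3 from compound 1 and the one to compound 3 from compound 2. The third, a number 13.3 percentage points higher from compound 1 to compound 2 (beyond the scatter), is the only one beyond the scatter, and it is modest. Within the data shown here, no measured compound carries the 4-chloro-3-(trifluoromethyl)phenyl group, so the data offer no direct precedent, and the range must stay wide. On these steps, no change beyond the scatter is expected, and the estimated step is a number 0.2 percentage points lower from compound 3 to compound 4 (within the scatter). Compound 4 is estimated at 70%, with an expected range of 52% to 85%.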

Compound 4, percent growth inhibition at one concentration: 39.5%
The estimate for compound 4 lay 30.5 percentage points above the measured number; measured number outside the range, below it.
By their numbers in this assay, from the lowest: compound 4; then compounds 1, 3 and 2 (each within the scatter of the next, the first and the last beyond it).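

At this amide-type nitrogen the earlier aryl swaps had moved the number in this assay little, but 4-chloro-3-(trifluoromethyl)phenyl lowers it against all three earlier compounds (a number 30.7 percentage points lower from compound 3 to compound 4 (beyond the scatter)) (a number 38 percentage points lower from compound 2 to compound 4 (beyond the scatter)) (a number 24.7 percentage points lower from compound 1 to compound 4 (beyond the scatter)). The position is therefore not indifferent to the aryl group it carries, and each of these steps is larger than any seen among the first three compounds. Nothing measured here bears on why the number falls with this group.

The compounds shown leave open whether the chloro or the trifluoromethyl group alone would bring the same fall. They also leave open how the number would respond to an amine or a carboxylic acid on this phenyl ring.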